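The source may hold more compounds than are shown below. What is called first, only, known or untested is meant among the compounds shown, and "the series" means these compounds.

Measured so far:
Compound 1 `CCCNC(=O)C1CCN(C(=O)c2cc3occc3n2Cc2ccc(OC)cc2)CC1`: 37200 nM
Compound 2 `CCCNC(=O)C1CCN(C(=O)c2cc3[nH]ccc3n2Cc2ccc(OC)cc2)CC1`: > 100000 nM

Among the measured compounds shown here, in an ADME assay on HEK-293T cells (Homo sapiens) for cytotoxicity, read by luminescence and CellTiter-Glo, with a stated time of 24 h (a higher number here means that more compound is tolerated, a lower number that less compound is tolerated), compound 1 gives 37200 nM, the only true number available. Compound 2 gives > 100000 nM, which is a limit of the assay and not a number.

Compound 3 `CCCNC(=O)C1CCN(C(=O)c2cc3oc(Br)cc3n2Cc2ccc(OC)cc2)CC1` has not yet been measured. It keeps the core of compound 1 but has bromo in place of hydrogen on an aromatic carbon, next to the ring oxygen (bromo in place of hydrogen on an aromatic carbon). For the measured compounds named here, no measured pair shows what this change does, so only a small expected step is proposed, a 1.5-fold lower number from compound 1 to compound 3 (0.17 log units; within the scatter), toward less compound tolerated and possibly no larger than the usual scatter. The estimate for compound 3 is 25000 nM, with an expected range from 9000 nM to 70000 nM.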

Compound 3, half-maximal cytotoxic concentration: 21900 nM
For compound 3 the middle estimate is 1.1-fold (0.06 log units) above the measured one; measured number inside the range.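

Bromo in place of hydrogen on an aromatic carbon, next to the ring oxygen, gives a 1.7-fold lower number from compound 1 to compound 3 (0.23 log units; within the scatter) in this assay. Among the compounds shown here, this is the first readable step in the set, and it shows that this one added heavy atom leaves the read-out within the usual scatter. Both compounds give true numbers, whereas one value in the set is a limit and not a number: the limit of > 100000 nM in this assay, at which 1 of the 3 values shown sits.

The compounds shown leave open what an amine, a carboxylic acid or a longer chain would do at this position. They also do not show whether chloro would match bromo here.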